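Swapping 4-methylphenyl for thiophen-2-yl on a sulfonyl sulfur

The source may report more compounds than this note shows. Statements on the series, on what has been measured and on what is new or still open speak of the compounds shown alone.

Measured so far:
compound 1 `Cc1ccc(S(=O)(=O)Nc2cc(SC(C)C(=O)N[C@@H](CC(C)C)B(O)O)c(O)c3ccccc23)cc1`: 8130 nM
compound 2 `CC(C)C[C@H](NC(=O)C(C)Sc1cc(NS(=O)(=O)c2ccccc2)c2ccccc2c1O)B(O)O`: 11100 nM; 5110 nM (2 entries)

Both compounds were tested in a functional assay on MDA-MB-231 cells (Homo sapiens) for antiproliferative activity, read by sulforhodamine B assay, with a stated time of 72 h; a lower number here means a stronger inhibitor, a higher number a weaker inhibitor. Compound 1 has one number, 8130 nM. Compound 2 has two entries rather than a single number, and the value of compound 1 falls inside the span they mark out: the several entries of compound 2 in this assay, 11100 nM; 5110 nM (2 entries). That span shows how far repeat readings of one compound can stray, so small gaps in this set carry little weight.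

Next comes compound 3 `CC(C)C[C@H](NC(=O)C(C)Sc1cc(NS(=O)(=O)c2cccs2)c2ccccc2c1O)B(O)O`. It differs from compound 1 in one place, with thiophen-2-yl in place of 4-methylphenyl on a sulfonyl sulfur. Among the measured compounds shown here, no measured pair shows directly what this swap does. Compound 2, at 11100 nM; 5110 nM (2 entries), stays in the same range as compound 1, so no change beyond the usual scatter is expected in this assay, and no firm direction either. The estimate amounts to a small expected step of a 1.0-fold lower number from compound 1 to compound 3 (0.01 log units; within the scatter). For compound 3 the estimated value is 8000 nM, with an expected range from 3000 nM to 20000 nM.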

Compound 3, half-maximal inhibitory concentration: 7450 nM
Compound 3: the middle estimate sits 1.1-fold (0.03 log units) above what was measured, within the range that was stated.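

In this assay, among the compounds shown here, the change of thiophen-2-yl in place of 4-methylphenyl on a sulfonyl sulfur now has a direct reading for the first time: a 1.1-fold lower number from compound 1 to compound 3 (0.04 log units; within the scatter). This pair shows that a five-membered aromatic ring holding one sulfur atom can stand on the sulfonyl sulfur in place of a six-membered carbon ring, and that the two compounds cannot be told apart by this read-out. The repeat readings of a close relative show how little weight so small a gap carries: the several entries of compound 2 in this assay, 11100 nM; 5110 nM (2 entries)

The groups on the sulfonyl sulfur shown so far are all aromatic rings without a net charge, so it remains open whether this position would respond to an amine, a carboxylic acid or a plain alkyl chain such as butyl. Going by these compounds, it is also open whether changes elsewhere on the shared core, for example at the chain carrying the boronic acid, would move the number further than any swap at this sulfonyl position has.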